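The source may hold more compounds than are shown below. What is called first, only, known or untested is meant among the compounds shown, and "the series" means these compounds.

Of the compounds shown here, two have so far been measured in a functional assay on the whole organism (aorta) with Rattus norvegicus as the target; a higher number here means a larger maximal response, a lower number a smaller maximal response. Compound 1 `CC1(C)C=C(n2ccccc2=O)c2cc(S(N)(=O)=O)ccc2O1` gives 77.5% in this assay, and compound 2 `CC1(C)C=C(n2ccccc2=O)c2cc(S(=O)(=O)Nc3ccc(C#N)cc3)ccc2O1` gives 84%. Among the compounds with values here, the single measured step, a number 6.5 percentage points higher from compound 1 to compound 2 (within the scatter), leaves compound 2 with the higher of the two numbers, though the gap to compound 1 lies within the usual scatter, so no order between them can be claimed. Compound 3 `CC1(C)C=C(n2ccccc2=O)c2cc(S(=O)(=O)Oc3ccccc3)ccc2O1` is the next member to go into this assay. Within the data shown here, it differs from compound 2 in one place: phenoxy in place of (4-cyanophenyl)amino on a sulfonyl sulfur The only measured step that bears on this position, a number 6.5 percentage points higher from compound 1 to compound 2 (within the scatter), was within the scatter, and nothing else measured here speaks to a phenoxy group on the sulfonyl sulfur. For compound 3 the expected step, a number 4 percentage points lower from compound 2 to compound 3 (within the scatter), is therefore one within the scatter, with no direction favoured. Compound 3 is estimated at 80%, with a range from 65% to 95%.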

Compound 3, largest response reached (Emax), in percent of the reference or control that the assay uses: 67.9%
Compound 3: the middle estimate sits 12.1 percentage points above what was measured; the measured number falls inside the stated range.
By their numbers in this assay, from the lowest: compounds 3, 1 and 2 (each within the scatter of the next, the first and the last beyond it).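

Phenoxy in place of (4-cyanophenyl)amino on a sulfonyl sulfur brings a number 16.1 percentage points lower from compound 2 to compound 3 (beyond the scatter) and is the first step at this position to clear the scatter, so the group on the sulfonyl sulfur can shift the maximal response in this assay. Phenoxy in place of amino gives only a number 9.6 percentage points lower from compound 1 to compound 3 (within the scatter) and sets no order, so the firm difference holds against the (4-cyanophenyl)amino group alone. Nothing measured here accounts for the larger step.

As far as these compounds go, the larger step swaps the linking nitrogen for oxygen and drops the nitrile at once, so it remains open which of the two changes carries it. From the compounds shown here alone, a phenylamino or a 4-cyanophenoxy group on the sulfonyl sulfur would separate them, and whether a small alkoxy group such as methoxy behaves like phenoxy also remains open.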